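The source may hold more compounds than are shown below. What is called first, only, known or untested is meant among the compounds shown, and "the series" means these compounds.

Working notes on the series. In a functional assay on LOX IMVI cells (Homo sapiens) for inhibition (a higher number here means a weaker inhibitor of growth, a lower number a stronger inhibitor of growth), compound 1 `COc1cc(/C=C/C(=O)c2cccc(-n3cc(-c4ccccc4)[nH]c3=O)c2)ccc1O` gives 1880 nM. Among the measured compounds shown here, compound 2 `COc1ccc(-c2cn(-c3cccc(C(=O)/C=C/c4ccc(O)c(OC)c4)c3)c(=O)[nH]2)cc1` gives 2440 nM in this assay, the highest of the two numbers, with compound 1 nearest; the step of a 1.3-fold higher number from compound 1 to compound 2 (0.11 log units; within the scatter) is the only measured step and stays within the scatter. Compound 3 `COc1cc(/C=C/C(=O)c2cccc(-n3cc(-c4ccc(Cl)cc4)[nH]c3=O)c2)ccc1O` carries the change (chloro in place of methoxy on an aromatic carbon), at the position para to a large group. For the measured compounds named here, no measured step covers a chloro in this place; the one step in hand, a 1.3-fold higher number from compound 1 to compound 2 (0.11 log units; within the scatter), shows that a change at this position from hydrogen to methoxy did not move the number beyond the scatter, and nothing in hand argues that the chloro will behave differently. The expected step from compound 2 to compound 3 is therefore a 1.2-fold lower number from compound 2 to compound 3 (0.09 log units; within the scatter), within the scatter. Compound 3 is estimated at 2000 nM in this assay, within 900 nM to 4500 nM.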

Compound 3, concentration for 50% growth inhibition: 1630 nM
Compound 3: middle estimate off by 1.2-fold (0.09 log units), on the high side, and the stated range covers the measured number.
By their numbers in this assay, from the lowest: compounds 3, 1 and 2 (each within the scatter of the next).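

Chloro is the second replacement for hydrogen at this position, para to a large group, and a 1.2-fold lower number from compound 1 to compound 3 (0.06 log units; within the scatter) in this assay stays as small as the methoxy step did. Direct exchange of the two substituents, the 4-methoxyphenyl to 4-chlorophenyl change, gives a 1.5-fold lower number from compound 2 to compound 3 (0.18 log units; within the scatter) and also does not separate the pair. Hydrogen, methoxy and chloro therefore cannot be told apart here, so among compounds 1, 2 and 3 the number does not depend on which of these groups is present, and no measurement in hand gives a reason for this.

Going by these compounds, whether an amine, a carboxylic acid or a longer chain at this position would move the number beyond the scatter remains open. The compounds shown also say nothing about changes elsewhere on the shared core.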